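Butyl for fluoro on the saturated ring carbon

The compounds below may be only part of what the source reports. "The series", "measured", "known", "first", "only" and "open" are said of these compounds alone.

Measured compounds:
- compound 1, `CC1(Sc2ccccc2)C(=O)N(c2ccccc2)c2ncccc21`: 0%
- compound 2, `CSC1(C)C(=O)N(c2ccccc2)c2ncccc21`: 34%
- compound 3, `CC1(F)C(=O)N(c2ccccc2)c2ncccc21`: 50%

In a functional assay on the whole organism (Pleural cavity) for inhibition, with Rattus norvegicus as the target, at a dose of 25 mg/kg (on this read-out lower numbers stand for less inhibition and higher numbers for more inhibition at the one dose given (going by the name of the read-out)), compound 3 stands highest of the three, with compound 2 next and compound 1 furthest away. Compound 4, `CCCCC1(C)C(=O)N(c2ccccc2)c2ncccc21`, is not yet measured; it differs from compound 3 by butyl in place of fluoro on a saturated ring carbon. Among the measured compounds shown here, the steps that bear on this change are a number 16 percentage points higher from compound 2 to compound 3 (beyond the scatter) and a number 50 percentage points higher from compound 1 to compound 3 (beyond the scatter); in both, a larger group on that carbon went with a lower number, the larger group the lower. Butyl is larger than fluoro and methylsulfanyl but smaller than phenylsulfanyl, so a drop is expected, estimated as a number 30 percentage points lower from compound 3 to compound 4 (beyond the scatter). For compound 4 the expected value is 20%, within a range from 0% to 45%.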

Compound 4, a percentage reported as inhibition, in the whole organism at one dose (the size of the read-out at that dose, not a potency): 21%
Estimate against measurement, compound 4: 1 percentage points below; low and high end bracket the measured number.
By their numbers in this assay, from the lowest: compound 1; then compound 4; then compound 2; then compound 3.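

In this assay, butyl on the saturated ring carbon gives a number 29 percentage points lower from compound 3 to compound 4 (beyond the scatter) and a number 13 percentage points lower from compound 2 to compound 4 (beyond the scatter), but a number 21 percentage points higher from compound 1 to compound 4 (beyond the scatter). A lower number than with fluoro therefore does not require sulfur on this carbon, since a plain carbon chain also shows it. Butyl places this chain between the methylsulfanyl and phenylsulfanyl groups in the order of the four compounds.

As far as these compounds go, whether a chain longer than butyl, a hydroxyl or an amine on this carbon would fit that order remains open. No measurement available here explains the differences among these groups.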